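The source may hold more compounds than are shown below. What is called first, only, known or untested is meant among the compounds shown, and "the series" means these compounds.

Measured in a functional assay on SK-BR-3 cells (Homo sapiens) for cytotoxicity, read by MTT assay, with a stated time of 72 h; a higher number here means that more compound is needed for the effect, a lower number that less compound is needed:
Compound 1 `CCc1cccc2c(OC)c(-c3occ(C)c3C(=O)OC)ccc12`: 1.2 ug/mL
Compound 2 `CCOC(=O)c1c(C)coc1-c1ccc2c(CC)cccc2c1OC`: 2.5 ug/mL
Compound 3 `CCOc1c(-c2occ(C)c2CO)ccc2c(CC)cccc12`: 8.8 ug/mL

Compound 2 is the second highest of these three numbers, with compound 1 lower and compound 3 higher. The account now turns to compound 4 `CCc1cccc2c(OC)c(-c3occ(C)c3COCC(F)(F)F)ccc12`, which differs from compound 2 in one place: (2,2,2-trifluoroethoxy)methyl in place of ethoxycarbonyl on an aromatic carbon. The exchange sits on an aromatic carbon of a five-membered aromatic ring with 1 oxygen.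

Among the compounds with values here, only one measured step bears on this change, and only loosely. It is a 2.1-fold higher number from compound 1 to compound 2 (0.32 log units; beyond the scatter), a modest step that alters the chain inside the carbonyl-bearing group but does not remove that group. Within the data shown here, no measured step shows what happens when ethoxycarbonyl is replaced outright, so neither the size nor the direction of the change is firmly anchored. Among the measured compounds shown here, compound 3, at 8.8 ug/mL, marks the highest number seen so far, and the expectation in this assay leans towards a modest move in that direction, of about the size of the one measured step. The step expected on this basis is a 1.8-fold higher number from compound 2 to compound 4 (0.26 log units; within the scatter), and a result within the scatter would not be surprising. For compound 4 the estimated value is 4.5 ug/mL, with an expected range of 1.3 ug/mL to 15 ug/mL.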

Compound 4, concentration for half-maximal effect: 5.3 ug/mL
The estimate for compound 4 lay 1.2-fold (0.07 log units) below the measured number; the measured number falls inside the stated range.
By their numbers in this assay, from the lowest: compound 1; then compound 2; then compounds 4 and 3 (each within the scatter of the next).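

In this assay the ester on this aromatic carbon of the five-membered aromatic ring can be replaced outright, which the earlier step, confined to the chain inside the ester, could not show. The exchange of ethoxycarbonyl for (2,2,2-trifluoroethoxy)methyl gives a 2.1-fold higher number from compound 2 to compound 4 (0.33 log units; beyond the scatter) as a modest move beyond the scatter, and the exchange of methoxycarbonyl for the same group gives a 4.4-fold higher number from compound 1 to compound 4 (0.65 log units; beyond the scatter) as a larger one, so both esters shown have lower numbers than the ether, while compound 4 still gives a measurable value without any carbonyl at this carbon. Nothing available explains why the number rises with this exchange.

The two new steps cannot tell whether the rise follows from losing the ester or from the particular chain that enters, since that chain changes the carbonyl, the length and the fluorine content together. From the compounds shown here alone, a plain ethoxymethyl chain, a carboxylic acid or an amide on this same carbon would be needed to separate these parts, and how far the number moves with any of them remains open.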